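The source may report more compounds than this note shows. Statements on the series, on what has been measured and on what is new or still open speak of the compounds shown alone.

Measured so far:
compound 1 `COC(=O)c1ccc(-c2cccc(NC(=O)C(Cl)Cl)c2)cc1` — > 50000 nM
compound 2 `CC(C)Oc1ccc(-c2cc(NC(=O)C(Cl)Cl)cc(-c3ccc(OC(C)C)cc3)c2)cc1` — 2860 nM
compound 3 `COc1cc(F)cc(-c2cc(NC(=O)C(Cl)Cl)cc(-c3cc(F)cc(OC)c3)c2)c1` — 2900 nM

In a functional assay on NCI-H460 cells (Homo sapiens) for cytotoxicity, read by MTT assay, with a stated time of 68 h (a lower number here means a stronger inhibitor, a higher number a weaker inhibitor), compound 1 gives > 50000 nM; this is a limit of the assay and not a number, as noted in the limit of > 50000 nM in this assay, at which 1 of the 3 values shown sits. Compound 2 gives 2860 nM in this assay. Compound 3 gives 2900 nM in this assay, and the values of compound 2 and compound 3 lie within the usual scatter of each other. Among the compounds with values here, compound 2 and compound 3 both carry two substituted aryl groups on the shared core, whereas compound 1 carries one; no single-point step connects compound 1 to either of them, so only the bare values can be set side by side.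

Compound 4 `O=C(Nc1cccc(-c2ccc(C(F)(F)F)cc2)c1)C(Cl)Cl` keeps the single-aryl arrangement of compound 1. The change is trifluoromethyl in place of methoxycarbonyl on an aromatic carbon. Within the data shown here, no measured step of this kind exists in the set, so the expectation rests on the limit of compound 1 alone. The step from compound 1 to compound 4 is expected to be small, an at least 1.4-fold lower number from compound 1 to compound 4 (0.15 log units; that floor lies within the scatter), with a real chance that this assay again reports only a limit. Compound 4 is therefore estimated at 35000 nM in this assay, within a range from 8000 nM to 100000 nM.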

Compound 4, half-maximal inhibitory concentration: 33600 nM
The estimate for compound 4 lay 1.0-fold (0.02 log units) above the measured number; the measured number falls inside the stated range.
By their numbers in this assay, from the lowest: compounds 2 and 3 (each within the scatter of the next); then compound 4. At a limit, above all of these: compound 1.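

In this assay, compound 4 gives 33600 nM, which is the only number among the compounds shown that carry one aryl group on the shared core. At this position, on an aromatic carbon para to a large group, trifluoromethyl in place of methoxycarbonyl gives an at least 1.4-fold lower number from compound 1 to compound 4 (0.17 log units; that floor lies within the scatter); this is only a floor, so the change is not shown to exceed the usual scatter, and its true size stays unknown. The entry for compound 1 is a limit of the assay and not a number, and this is what restricts the step to a floor: the limit of > 50000 nM in this assay, at which 1 of the 4 values shown sits.

The compounds shown leave open how far the value at this position depends on the group placed there, for instance whether an amine or a carboxylic acid in place of trifluoromethyl would give a number or another limit. Within the data shown here, they also leave open what a second aryl group contributes, as no single-place step links compound 4 to compound 2 or compound 3, and those compounds can only be set beside it by their printed values.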